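This account rests on a few compounds, and the source may have more. Where it says the series, first, only, none or still open, it means among the compounds named here.

Working notes on the series.

The shared core is a pyrrolidine polyol carrying a hydroxymethyl group at the quaternary carbon, varied only in the group on that carbon. Compound 1 `OC[C@]1(c2ccc(F)cc2)NC[C@H](O)[C@H]1O` is tested in an assay on isolated protein for inhibition of alpha-galactosidase (Coffea arabica), tested at 1000 uM (a higher number here means more inhibition at the concentration tested (going by the name of the read-out), a lower number less inhibition), and gives 0%. Compound 2 `OC[C@@]1(c2cccc(F)c2)NC[C@@H](O)[C@@H]1O` in this assay gives 0%, which is level with compound 1 at the digits shown. Compound 3 `CCCC[C@]1(CO)NC[C@@H](O)[C@@H]1O` in this assay gives 4.6%, a number within the scatter of compound 1, so the three measured compounds show no separation in this assay. Compound 1 stands with compound 2 at the bottom of the three numbers, but the spread is within the scatter.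

Compound 4 `Cc1ccc([C@@]2(CO)NC[C@H](O)[C@H]2O)cc1` is not yet measured. It differs from compound 1 by methyl in place of fluoro on an aromatic carbon. Among the compounds with values here, no step between measured compounds is available for this change, and all measured compounds sit near zero in this assay. For compound 4 the step from compound 1 is expected to be none beyond the scatter, estimated as a number 2 percentage points higher from compound 1 to compound 4 (within the scatter). Compound 4 is thus estimated at 2% in this assay, with a range from 0% to 12%.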

Compound 4, a percentage reported as inhibition, at one concentration (the size of the read-out at that concentration, not a potency): 0%
For compound 4 the middle estimate is 2 percentage points above the measured one, and the stated range covers the measured number.
By their numbers in this assay, from the lowest: compounds 1, 2, 4 and 3 (each within the scatter of the next).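

Methyl in place of fluoro on an aromatic carbon, para to a group of 9 heavy atoms, gives no change at the digits printed from compound 1 to compound 4 (within the scatter) in this assay, the first step in the series that can be read at a single place. It shows that this exchange at this position brings no inhibition into view at the concentration tested, but with both compounds at the bottom of the read-out, it gives no measure of how much the position matters. No measurement of any property of either group bears on this result.

On these data alone, whether an amine or a carboxylic acid on this aromatic carbon would lift the read-out in this assay stays open. Also open, as far as these compounds go, is whether compound 1 and compound 4 would stay level against a different enzyme.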